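The compounds below may be only part of what the source reports. "The series", "measured", "known", "first", "only" and "open" are said of these compounds alone.

The measured compounds:
Compound 1, `O=C(N[C@H]1CCC[C@H](NC(=O)c2cccc(Cl)c2)C1)c1ccncc1`, in a functional assay on HEK293 cells for antagonist activity at metabotropic glutamate receptor 5 (Homo sapiens), read by FLIPR and calcium flux (on this read-out higher numbers stand for weaker inhibition and lower numbers for stronger inhibition), compound 1 gives 300 nM.
Compound 2, `Cc1cccc(C(=O)N[C@H]2CCC[C@H](NC(=O)c3cccc(Cl)c3)C2)n1`, in this assay compound 2 gives 290 nM.

Compound 2 sits essentially on the same level as compound 1: the change a 1.0-fold lower number from compound 1 to compound 2 (0.01 log units; within the scatter) lies within the scatter, so neither compound can be called the stronger of the two. Compound 3, `O=C(N[C@H]1CCC[C@H](NC(=O)c2ccccc2F)C1)c1cccc(Cl)c1`, is not yet measured. It differs from compound 2 in one place: 2-fluorophenyl in place of 6-methylpyridin-2-yl on a carbonyl carbon. Going by the values given here, the only measured step that bears on it is the earlier exchange of one aromatic group for another on the same carbonyl carbon, a 1.0-fold lower number from compound 1 to compound 2 (0.01 log units; within the scatter), which produced no shift beyond the scatter. On that basis a step of no more than the scatter is expected in this assay, with no direction favoured, so compound 3 is estimated to give 300 nM with a range from 120 nM to 750 nM, the expected step being a 1.0-fold higher number from compound 2 to compound 3 (0.01 log units; within the scatter).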

Compound 3, half-maximal inhibitory concentration: 175 nM
Beside the measured number, compound 3's estimate is 1.7-fold (0.23 log units) above it; the measured number falls inside the stated range.
By their numbers in this assay, from the lowest: compounds 3, 2 and 1 (each within the scatter of the next).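

Replacing the aromatic group on the carbonyl carbon with 2-fluorophenyl gives a 1.7-fold lower number from compound 2 to compound 3 (0.22 log units; within the scatter) and a 1.7-fold lower number from compound 1 to compound 3 (0.23 log units; within the scatter) in this assay. Both earlier groups were six-membered aromatic rings with 1 hetero atom and 1 hydrogen-bond acceptor, whereas 2-fluorophenyl is a ring of carbon only with 0 hydrogen-bond acceptors, so this position does not need a ring nitrogen to stay within the scatter of compound 1 and compound 2 in this read-out. No accompanying measurement explains why these exchanges leave the numbers so close.

Going by these compounds, all three groups at this position are six-membered aromatic rings, so it remains open whether the level would hold with a non-aromatic group such as cyclohexyl or with a carboxylic acid on the ring. A single fluorine also says nothing about how a methoxy or trifluoromethyl group would fare on the same carbon-only ring.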